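Taking the piperidin-1-yl group off compound 3

The source may report more compounds than this note shows. Statements on the series, on what has been measured and on what is new or still open speak of the compounds shown alone.

In an ADME assay for permeability, using PAMPA, at pH 7.4 (on this read-out higher numbers stand for higher permeability and lower numbers for lower permeability), compound 3 (`Cc1ccc(-c2nc3ccccc3s2)cc1NC(=O)c1cc([N+](=O)[O-])c(N2CCCCC2)cc1Cl`) gives < 1 10^-6 cm/s, which is a limit of the assay and not a number. Compound 1 (`Cc1cc(NC(=O)c2cc([N+](=O)[O-])ccc2Cl)cc(-c2nc3ccccc3o2)c1O`) gives a number, 105 10^-6 cm/s, and so does compound 2 (`Cc1cc(NC(=O)c2cc([N+](=O)[O-])ccc2Cl)cc(-c2nc3ccccc3s2)c1O`), at 48 10^-6 cm/s. Compound 4 (`Cc1ccc(-c2nc3ccccc3s2)cc1NC(=O)c1cc([N+](=O)[O-])ccc1Cl`) has hydrogen in place of piperidin-1-yl on an aromatic carbon. Within the data shown here, the only measured step, a 2.2-fold lower number from compound 1 to compound 2 (0.34 log units; beyond the scatter), is modest and concerns 1,3-benzothiazol-2-yl in place of 1,3-benzoxazol-2-yl, a different change, so it gauges this one only loosely. A clearly larger rise is expected, with compound 2 at 48 10^-6 cm/s as the guide to its height. The expected change is an at least 30-fold higher number from compound 3 to compound 4 (1.47 log units; beyond the scatter). The estimate for compound 4 is 30 10^-6 cm/s, with an expected range of 4 10^-6 cm/s to 110 10^-6 cm/s.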

Compound 4, apparent permeability: 41 10^-6 cm/s
For compound 4 the middle estimate is 1.4-fold (0.14 log units) below the measured one; low and high end bracket the measured number.
By their numbers in this assay, from the lowest: compounds 4 and 2 (each within the scatter of the next); then compound 1. At a limit, below all of these: compound 3.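

In this assay, hydrogen in place of piperidin-1-yl on this aromatic carbon, ortho to a nitro group, gives an at least 41-fold higher number from compound 3 to compound 4 (1.61 log units; beyond the scatter), the only large step shown. The value of compound 3 is a limit of the assay and not a number, so the full size of this step stays unknown: the limit of < 1 10^-6 cm/s in this assay, at which 1 of the 4 values shown sits.

Going by these compounds, whether a small amine such as dimethylamino or a carboxylic acid on this carbon would hold the number near that of compound 4 remains open. So does whether the piperidin-1-yl ring itself matters, or any group larger than hydrogen here would do the same.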